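A few compounds are considered here, and "the series" means these few. Any claim that something is new, unique, unknown or untested is made for them only; others in the source may bear on it.

Measured compounds:
- compound 1, `O=C1/C(=C/c2cccnc2)CN(S(=O)(=O)c2ccc(F)cc2)C/C1=C\c1ccccc1F` — in a functional assay on QGY-7703 cells (Homo sapiens) for cytotoxicity, read by MTT assay, with a stated time of 24 h (on this read-out lower numbers stand for stronger inhibition and higher numbers for weaker inhibition), compound 1 gives 15300 nM.
- compound 2, `O=C1/C(=C/c2cccnc2)CN(S(=O)(=O)c2ccc(Cl)cc2)C/C1=C\c1ccccc1F` — compound 2 gives 12100 nM.
- compound 3, `O=C1/C(=C/c2cccnc2)CN(S(=O)(=O)c2ccc(F)cc2)C/C1=C\c1ccccc1C(F)(F)F` — compound 3 gives 6030 nM.

The unmeasured member is compound 4, `O=C1/C(=C/c2cccnc2)CN(S(=O)(=O)c2ccc(Cl)cc2)C/C1=C\c1ccccc1C(F)(F)F`.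

Two changes run through the series. The first is chloro in place of fluoro on an aromatic carbon; it gave a 1.3-fold lower number from compound 1 to compound 2 (0.10 log units; within the scatter). Within the data shown here, the second sets compound 3 apart from compound 1: trifluoromethyl in place of fluoro on an aromatic carbon; it gave a 2.5-fold lower number from compound 1 to compound 3 (0.40 log units; beyond the scatter), the one step here that is read as beyond the scatter.

Compound 4 relates to compound 3 as compound 2 relates to compound 1: chloro in place of fluoro on an aromatic carbon. The place is the same in both pairs, so this is the same change, made once on the core of compound 1 and once on the core of compound 3. Among the measured compounds shown here, its only measured instance is small and within the scatter, so a small step is expected here too, resting on a 1.3-fold lower number from compound 1 to compound 2 (0.10 log units; within the scatter).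

Compound 4 is therefore expected to give a 1.2-fold lower number from compound 3 to compound 4 (0.08 log units; within the scatter) in this assay. The estimate for compound 4 is 5000 nM, with a range from 2500 nM to 10000 nM.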

Compound 4, half-maximal inhibitory concentration: 3440 nM
Estimate against measurement, compound 4: 1.5-fold (0.16 log units) above; the measured number falls inside the stated range.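

In this assay, chloro in place of fluoro gives a 1.8-fold lower number from compound 3 to compound 4 (0.24 log units; within the scatter), and this step carries over from the core of compound 1 to the core of compound 3 without a detectable difference: the same change on two cores in this assay, a 1.3-fold lower number (0.10 log units; within the scatter) from compound 1 to compound 2 and a 1.8-fold lower number (0.24 log units; within the scatter) from compound 3 to compound 4, 1.4-fold (0.14 log units) apart, within the scatter of two such steps. Trifluoromethyl in place of fluoro gives a 3.5-fold lower number from compound 2 to compound 4 (0.55 log units; beyond the scatter), and this step also carries over, here between the cores of compound 1 and compound 2: the same change on two cores in this assay, a 2.5-fold lower number (0.40 log units; beyond the scatter) from compound 1 to compound 3 and a 3.5-fold lower number (0.55 log units; beyond the scatter) from compound 2 to compound 4, 1.4-fold (0.14 log units) apart, within the scatter of two such steps. These comparisons show that each change behaves alike on the two cores tested, but they rest on a single set of four compounds in one assay, the chloro step stays within the scatter on both cores, and nothing follows for other cores.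

Still open, on these data alone, is whether a methoxy group, a nitrile or an amine in place of the chloro would shift the number in the same way on both cores. Also open, as far as these compounds go, is whether the two steps would keep their size in other cell types or over other exposure times.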